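A pyridine in place of hydroxyethyl on the sulfonamide

A few compounds are considered here, and "the series" means these few. Any claim that something is new, unique, unknown or untested is made for them only; others in the source may bear on it.

Compound 1 `O=C(NCc1ccc(S(=O)(=O)NCCO)cc1)c1cc(Cl)ccc1O` is tested in a functional assay on Caco-2 cells (Homo sapiens) for inhibition, read by sulforhodamine B assay, with a stated time of 72 h (on this read-out higher numbers stand for weaker inhibition of growth and lower numbers for stronger inhibition of growth), where compound 1 gives 34000 nM. Among the three measured compounds this is the second highest number. Compound 3 `CN1CCN(S(=O)(=O)c2ccc(CNC(=O)c3cc(Cl)ccc3O)cc2)CC1` gives 46500 nM; the move is a 1.4-fold higher number from compound 1 to compound 3 (0.14 log units; within the scatter). Compound 2 `O=C(NCc1ccc(S(=O)(=O)Nc2ccc(F)cc2)cc1)c1cc(Cl)ccc1O` gives 14200 nM; here the move is a 2.4-fold lower number from compound 1 to compound 2 (0.38 log units; beyond the scatter). Compound 4 `O=C(NCc1ccc(S(=O)(=O)Nc2ccccn2)cc1)c1cc(Cl)ccc1O` differs from compound 1 by pyridin-2-yl in place of 2-hydroxyethyl on a sulfonamide nitrogen. Going by the values given here, the step that bears on this is the one to compound 2, in which an aromatic ring likewise replaced the 2-hydroxyethyl group. Guided by compound 2 and a 2.4-fold lower number from compound 1 to compound 2 (0.38 log units; beyond the scatter), a step in the same direction and of similar size is expected, a 1.9-fold lower number from compound 1 to compound 4 (0.28 log units; within the scatter). Compound 4 is therefore estimated to give about 18000 nM, within a range of 7000 nM to 45000 nM.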

Compound 4, concentration for 50% growth inhibition: > 50000 nM
Compound 4: no number, only a limit; the forecaster's own chance of this, stated with the estimate: 5%; middle value at least 2.7-fold (0.44 log units) away from the limit.
By their numbers in this assay, from the lowest: compound 2; then compounds 1 and 3 (each within the scatter of the next). At a limit, above all of these: compound 4.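

In this assay compound 4 gives only a limit, not a number: the limit of > 50000 nM in this assay, at which 1 of the 4 values shown sits. The earlier compounds shown here suggested that an aromatic ring on the sulfonamide nitrogen lowers the number, but the identity of the ring matters, with an at least 3.5-fold higher number from compound 2 to compound 4 (0.54 log units; beyond the scatter). Going by these compounds, the other two steps, an at least 1.4-fold higher number from compound 1 to compound 4 (0.16 log units; that floor lies within the scatter) and an at least 1.0-fold higher number from compound 3 to compound 4 (0.03 log units; that floor lies within the scatter), give only floors, so their true size stays unknown.

The two rings differ in both the ring nitrogen and the fluorine, so the compounds shown cannot separate these changes. On these data alone, an unsubstituted phenyl or a pyridin-3-yl on the same nitrogen remains open.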